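The compounds below may be only part of what the source reports. "The series", "measured", "known", "first", "only" and "open" are said of these compounds alone.

Compound 1 `OC[C@H]1O[C@@H](n2cnc3c(NCc4ccccc4Cl)ncnc32)[C@H](O)[C@@H]1O` in a functional assay on HOS cells (Homo sapiens) for antiproliferative activity, with a stated time of 72 h (on this read-out higher numbers stand for weaker inhibition and lower numbers for stronger inhibition), gives > 166000 nM, a limit of the assay and not a number.
Compound 2 `OC[C@H]1O[C@@H](n2cnc3c(NCc4ccc(F)cc4Cl)ncnc32)[C@H](O)[C@@H]1O` in this assay gives > 166000 nM, again a limit.
Compound 3 `OC[C@H]1O[C@@H](n2cnc3c(NCc4cccc(O)c4O)ncnc32)[C@H](O)[C@@H]1O` in this assay gives > 166000 nM, also a limit.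

Compound 1 therefore stands only at a limit in this assay, as do both other measured compounds (the limit of > 166000 nM in this assay, at which 3 of the 3 values shown sit). Compound 4 `Cc1cccc(CNc2ncnc3c2ncn3[C@@H]2O[C@H](CO)[C@@H](O)[C@H]2O)c1O` differs from compound 1 by 2-hydroxy-3-methylphenyl in place of 2-chlorophenyl on a saturated chain carbon bound to a nitrogen on an aromatic ring. The closest measured steps exchange the same 2-chlorophenyl for a hydroxylated ring, a step that the two limits leave unreadable from compound 1 to compound 3 and a step that the two limits leave unreadable from compound 2 to compound 3, but both stay unreadable because of the limit of > 166000 nM in this assay, at which 3 of the 3 values shown sit. No readable change is therefore expected, a step that the limit leaves unreadable from compound 1 to compound 4, and compound 4 is estimated to sit near 200000 nM, between 50000 nM and 800000 nM, most likely reported as a limit again.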

Compound 4, half-maximal inhibitory concentration: > 166000 nM
Compound 4 was reported as a limit (the forecaster's own chance of this, stated with the estimate: 85%); the middle value is on the limit's open side.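

Compound 4 joins compounds 1, 2 and 3 at the same assay limit, so none of the steps among these four compounds can be read: the limit of > 166000 nM in this assay, at which 4 of the 4 values shown sit.

What the compounds shown leave open is whether any change to this benzyl group lowers the value in this assay to a measurable number.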